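A few compounds are considered here, and "the series" means these few. Any claim that something is new, unique, unknown or untested is made for them only; others in the source may bear on it.

Three compounds on the shared core have been run in an ADME assay on BV-2 cells (Mus musculus) for cytotoxicity, read by MTT assay, with a stated time of 48 h, tested at 10 uM; on this read-out lower numbers stand for a stronger effect and higher numbers for a weaker effect at the one concentration tested. Compound 1 `Cc1ccc(S(=O)(=O)n2cc(/C=N\c3ccc(N4CCOCC4=O)cc3)c3ccccc32)cc1` gives 86.4%. Compound 2 `O=C1COCCN1c1ccc(/N=C\c2cn(C(=O)c3ccccc3)c3ccccc23)cc1` gives 88.6%. Compound 3 `O=C1COCCN1c1ccc(/N=C\c2cn(Cc3ccccc3)c3ccccc23)cc1` gives 91.3%, the highest of the three numbers, though the steps of a number 4.9 percentage points higher from compound 1 to compound 3 (within the scatter) and a number 2.7 percentage points higher from compound 2 to compound 3 (within the scatter) both fall within the scatter, as does a number 2.2 percentage points higher from compound 1 to compound 2 (within the scatter). Compound 4 `O=C1COCCN1c1ccc(/N=C\c2cn(Cc3ccc(F)cc3)c3ccccc23)cc1` differs from compound 3 by fluoro in place of hydrogen on an aromatic carbon. Among the compounds with values here, none of the measured steps bears directly on this change: all three exchange the group on the aromatic nitrogen, and none left the scatter, so no step beyond the scatter is expected in this assay here either. Compound 4 is therefore expected to give 91%, between 82% and 99%, and the expected step is a number 0.3 percentage points lower from compound 3 to compound 4 (within the scatter).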

Compound 4, a percentage reported as activity, at one concentration (the size of the read-out at that concentration, not a potency): 90%
For compound 4 the middle estimate is 1 percentage points above the measured one, within the range that was stated.
By their numbers in this assay, from the lowest: compounds 1, 2, 4 and 3 (each within the scatter of the next).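

Fluoro in place of hydrogen on this aromatic carbon, para to a large group, gives a number 1.3 percentage points lower from compound 3 to compound 4 (within the scatter) in this assay, so this position has now been probed directly and the step stays within the scatter. 4-Fluorobenzyl on the aromatic nitrogen also stays within the scatter of the other groups there, with a number 1.4 percentage points higher from compound 2 to compound 4 (within the scatter) and a number 3.6 percentage points higher from compound 1 to compound 4 (within the scatter). No available evidence bears on this result.

Going by these compounds, whether an amine or a carboxylic acid at this same carbon would leave the scatter remains open. The same holds for a longer chain on the aromatic nitrogen.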